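Pyrrole for Phenyl on a Fatty Acid Receptor Agonist Scaffold

A few compounds are considered here, and "the series" means these few. Any claim that something is new, unique, unknown or untested is made for them only; others in the source may bear on it.

Measured compounds:
compound 1 `Cc1cc(OCCCS(C)(=O)=O)cc(C)c1-c1cccc(COc2ccc(S(=O)(=O)CC(=O)O)cc2)c1`: 170 nM
compound 2 `Cc1ccccc1-c1cccc(COc2ccc(S(=O)(=O)CC(=O)O)cc2)c1`: 46.8 nM

The study measures agonism in a functional assay on CHO cells for agonist activity at Free fatty acid receptor 1 (Homo sapiens), read by FLIPR and calcium flux; a higher number here means that more compound is needed for the effect, a lower number that less compound is needed. Among the measured compounds shown here, compound 1 gives 170 nM in this assay, while compound 2 gives 46.8 nM, the lowest of the two numbers; the gap between them is beyond the scatter, but the two structures differ in more than one place, so no single step can be assigned to it.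

The next compound, compound 3 `Cc1ccc(C)n1-c1cccc(COc2ccc(S(=O)(=O)CC(=O)O)cc2)c1`, has not yet been measured in this assay. It departs from compound 2 by one change (2,5-dimethyl-1H-pyrrol-1-yl in place of 2-methylphenyl on an aromatic carbon). The leaving group and the entering group are equal in heavy atom count, but the entering group carries one hydrogen-bond acceptor and a five-membered aromatic ring with one hetero atom in place of a six-membered aromatic ring of carbon only.

For the measured compounds named here, no measured pair shows a step of this kind, so the expectation rests on compound 2 alone. The author expects a modest loss, a 2.6-fold higher number from compound 2 to compound 3 (0.41 log units; beyond the scatter), because compound 2 already gives 46.8 nM and the change leaves the rest of the core untouched. Compound 3 is therefore estimated at 120 nM, within a range of 40 nM to 400 nM.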

Compound 3, half-maximal effective concentration: 129 nM
Compound 3: middle estimate off by 1.1-fold (0.03 log units), on the low side; measured number inside the range.
By their numbers in this assay, from the lowest: compound 2; then compounds 3 and 1 (each within the scatter of the next).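

In this assay, among the compounds shown here, the exchange of 2-methylphenyl for 2,5-dimethyl-1H-pyrrol-1-yl gives a 2.8-fold higher number from compound 2 to compound 3 (0.44 log units; beyond the scatter) and so provides the first step in this set that can be tied to one place; it is modest in size, yet beyond the scatter. It shows that this position, on an aromatic carbon of a six-membered aromatic ring of carbon only and meta to a large group, can carry a five-membered aromatic ring with one hetero atom at equal heavy atom count, with some loss but with agonism still measurable. Nothing measured here explains the rise in the number, so the step stands as an observation only.

The compounds shown leave open whether the two methyl groups of the pyrrole matter, since an unsubstituted pyrrol-1-yl, a thiophene or a pyridine at this position would each separate the effect of the ring from that of its methyl groups. They also leave open whether the same exchange would cost as much on a core that carries a longer chain on the ring, such as a methoxyethoxy group.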